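This account rests on a few compounds, and the source may have more. Where it says the series, first, only, none or still open, it means among the compounds named here.

Working notes on the series.

Compound 1 `c1ccc(COC[C@H]2OCC[C@@H](OCc3ccccc3)[C@@H]2OCc2ccccc2)cc1` is the parent; in a functional assay on HOS cells (Homo sapiens) for antiproliferative activity, read by sulforhodamine B assay (a lower number here means a stronger inhibitor of growth, a higher number a weaker inhibitor of growth), compound 1 gives 22200 nM. Compound 2 `O[C@H]1CO[C@H](COCc2ccccc2)[C@@H](OCc2ccccc2)[C@@H]1OCc1ccccc1` carries a hydroxy in place of hydrogen on a saturated ring carbon, and in this assay compound 2 gives 37900 nM. The step of a 1.7-fold higher number from compound 1 to compound 2 (0.23 log units; within the scatter) is within the scatter, so the two numbers cannot be told apart. Compound 3 `O[C@@H]1[C@@H](OCc2ccccc2)[C@H](OCc2ccccc2)[C@@H](COCc2ccccc2)O[C@@H]1CC1CCCCC1` adds a cyclohexylmethyl in place of hydrogen on a saturated ring carbon of compound 2. In this assay compound 3 gives <= 20700 nM, which is a limit of the assay and not a number. The step of an at least 1.8-fold lower number from compound 2 to compound 3 (0.26 log units; that floor lies within the scatter) rests on that limit (the limit of <= 20700 nM in this assay, at which 1 of the 3 values shown sits), and its floor lies within the scatter.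

Compound 4 `O[C@@H]1[C@@H](OCc2ccccc2)[C@H](OCc2ccccc2)[C@@H](COCc2ccccc2)O[C@H]1c1ccccc1` is not yet measured. Relative to compound 2 the change is phenyl in place of hydrogen on a saturated ring carbon. Going by the values given here, the only step that bears on it is the one from compound 2 to compound 3, where a larger saturated group at the same place gave a number at the limit. For compound 4 a small step downward in this assay is expected, a 1.9-fold lower number from compound 2 to compound 4 (0.28 log units; within the scatter), though a measurement within the scatter of compound 2 would not be surprising. The estimate for compound 4 is 20000 nM, with a range from 7000 nM to 50000 nM.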

Compound 4, concentration for 50% growth inhibition: > 50000 nM
Compound 4 ended at the assay's limit; the forecaster's own chance of this, stated with the estimate: 30%; middle value at least 2.5-fold (0.39 log units) from the limit.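

In this assay, phenyl in place of hydrogen on the saturated ring carbon next to the ring oxygen and next to the ring atom that bears a hydroxy group gives no lower number, with an at least 1.3-fold higher number from compound 2 to compound 4 (0.12 log units; that floor lies within the scatter), so this step shows no gain in growth inhibition, and no loss can be claimed from its floor. Compound 4 stands at a limit of the assay and not at a number: the limit of > 50000 nM in this assay, at which 1 of the 4 values shown sits. Compound 3, with cyclohexylmethyl on the same ring carbon, gives <= 20700 nM, also a limit and not a number, and since the two limits do not overlap, this position does not respond alike to the two carbon groups.

Going by these compounds, how far the true values of compound 3 and compound 4 lie beyond their limits remains unknown, so the size of the gap between the two groups cannot be stated. Also open, on these data alone, is how this ring carbon responds to a group of another kind, such as an aminomethyl group, a carboxylic acid or a longer straight alkyl chain.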